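This account rests on a few compounds, and the source may have more. Where it says the series, first, only, none or still open, it means among the compounds named here.

Measured in a functional assay on the whole organism for inhibition, with Mus musculus as the target; on this read-out higher numbers stand for an effect only at larger amounts of compound and lower numbers for an effect already at smaller amounts:
- compound 1 `CC(C)c1ccc(C2CN(C)Cc3c(N)cccc32)cc1`: 68 mg/kg
- compound 2 `CCCNC(=O)Nc1cccc2c1CN(C)CC2c1ccccc1`: > 80 mg/kg (a limit, not a number)
- compound 3 `CCOC(=O)Nc1cccc2c1CN(C)CC2c1ccc(Cl)cc1`: 0.6 mg/kg

Compound 2 gives no number: it stands at the limit of > 80 mg/kg in this assay, at which 1 of the 3 values shown sits. Compound 4 `CCCCOC(=O)Nc1cccc2c1CN(C)CC2c1ccccc1` has not yet been measured in this assay. It keeps the rest of compound 2 and has butoxy in place of propylamino on a carbonyl carbon.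

Among the measured compounds shown here, no measured step covers this change, so the expectation rests on thin ground. Compound 3 also carries an alkoxy group on a carbonyl carbon, and compound 3 gives 0.6 mg/kg. On that single value, a move well beyond the scatter toward smaller doses is expected in this assay, though probably not all the way to the value of compound 3. Counted from the limit, the estimated change is an at least 20-fold lower number from compound 2 to compound 4 (1.30 log units; beyond the scatter). For compound 4 the expected value is 4 mg/kg, with an estimated range from 0.6 mg/kg to 30 mg/kg.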

Compound 4, dose for half-maximal effect: 2.6 mg/kg
Estimate against measurement, compound 4: 1.5-fold (0.19 log units) above; the range from low to high includes it.
By their numbers in this assay, from the lowest: compound 3; then compound 4; then compound 1. At a limit, above all of these: compound 2.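

Butoxy in place of propylamino on a carbonyl carbon, with the rest of the molecule kept, gives an at least 30-fold lower number from compound 2 to compound 4 (1.48 log units; beyond the scatter) in this assay, the only direct reading of this position among the compounds shown. Compound 2 gives a limit, not a number: the limit of > 80 mg/kg in this assay, at which 1 of the 4 values shown sits.
The step therefore sets a minimum size, and it shows that this single exchange is enough to turn a compound with no number into one with a measured dose.

The exchange alters the atom bound to the carbonyl and the chain at once, so a butylamino or a propoxy group in the same place would be needed to tell these two apart. Compound 3 differs from compound 4 in more than one place, which leaves the separate contributions of its ethoxy and chloro groups open.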